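The source may hold more compounds than are shown below. What is called first, only, known or untested is meant among the compounds shown, and "the series" means these compounds.

Compound 2 `O=c1cc(Cn2cc(CCCCO)nn2)c2ccc(O)cc2o1` is the starting point. In a functional assay on HeLa cells (Homo sapiens) for inhibition, read by MTT assay, with a stated time of 72 h (on this read-out lower numbers stand for stronger inhibition and higher numbers for weaker inhibition), compound 2 gives > 100000 nM, which is a limit of the assay rather than a number. Compound 1 `CC(O)c1cn(Cc2cc(=O)oc3cc(O)ccc23)nn1` likewise gives > 100000 nM, also a limit. Compound 3 `O=c1cc(Cn2cc(-c3ccc(Br)cc3)nn2)c2ccc(O)cc2o1` gives 40200 nM. One step, a step that the two limits leave unreadable from compound 1 to compound 2, stays unreadable, whereas an at least 2.4-fold lower number from compound 2 to compound 3 (0.39 log units; beyond the scatter) and an at least 2.4-fold lower number from compound 1 to compound 3 (0.39 log units; beyond the scatter) show that replacing either hydroxyalkyl chain by 4-bromophenyl lowers the number; the weight of the limit of > 100000 nM in this assay, at which 2 of the 3 values shown sit, leaves the true size of those steps open. Compound 4 `O=c1cc(Cn2cc(CSC(=S)N3CCNCC3)nn2)c2ccc(O)cc2o1` carries a group of 9 heavy atoms (5 carbon, 2 nitrogen, 2 sulfur; one six-membered non-aromatic ring with 2 hetero atoms) in place of a group of 4 heavy atoms (3 carbon, 1 oxygen; no ring), on a saturated chain carbon bound to an aromatic carbon. Among the compounds with values here, no measured step involves such a group, so the account expects compound 4 to give 70000 nM, within 20000 nM to 200000 nM, a step of an at least 1.4-fold lower number from compound 2 to compound 4 (0.15 log units; that floor lies within the scatter) that is expected to stay near the scatter.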

Compound 4, half-maximal inhibitory concentration: > 100000 nM
Compound 4: only a limit was reported (the forecaster's own chance of this, stated with the estimate: 50%); middle value at least 1.4-fold (0.15 log units) from the limit.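

Within the data shown here, compound 2 and compound 4 both sit at a limit of the assay, so no step between them can be read. The compounds shown leave open the true values of compound 1, compound 2 and compound 4, which all rest on one bound: the limit of > 100000 nM in this assay, at which 3 of the 4 values shown sit.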